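Hydroxypyridinylmethylamino Replaces Bis(cyclopropylmethyl)amino on the Anilide Ring

A few compounds are considered here, and "the series" means these few. Any claim that something is new, unique, unknown or untested is made for them only; others in the source may bear on it.

Two measured compounds share a core. Compound 1 `CCCCCCCCC(C)Nc1ccc(NC(=O)c2cc(Cl)ccc2O)c(Cl)c1` and compound 2 `O=C(Nc1ccc(N(CC2CC2)CC2CC2)cc1Cl)c1cc(Cl)ccc1O` were both tested in an ADME assay on A549 cells (Homo sapiens) for cytotoxicity, read by resazurin assay, with a stated time of 48 h; on this read-out lower numbers stand for higher toxicity in this test and higher numbers for lower toxicity in this test. In this assay compound 1 gives 21900 nM. In this assay compound 2 gives 12800 nM; this number and that of compound 1 lie within the usual scatter of each other, so on this read-out the two compounds cannot be told apart. Going by the values given here, no single-point step between them has been worked out, as they differ in more than one place.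

Compound 3 `O=C(Nc1ccc(NCc2ccc(O)nc2)cc1Cl)c1cc(Cl)ccc1O` has not yet been measured. It differs from compound 2 in one place: ((6-hydroxypyridin-3-yl)methyl)amino in place of bis(cyclopropylmethyl)amino on an aromatic carbon. Among the compounds with values here, nothing among the measured compounds shows how such an exchange moves the half-maximal cytotoxic concentration, so any expectation rests on the value of compound 2 alone. Compound 3 is expected to give a number near that of its parent, with at most a small move toward a higher number. The estimated step of a 1.6-fold higher number from compound 2 to compound 3 (0.19 log units; within the scatter) is expected to stay within or only just beyond the scatter. In this assay compound 3 is estimated at 20000 nM, with a range from 8000 nM to 50000 nM.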

Compound 3, half-maximal cytotoxic concentration: 98500 nM
Beside the measured number, compound 3's estimate is 4.9-fold (0.69 log units) below it, and the stated range ends below it.
By their numbers in this assay, from the lowest: compounds 2 and 1 (each within the scatter of the next); then compound 3.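

In this assay, putting ((6-hydroxypyridin-3-yl)methyl)amino in place of bis(cyclopropylmethyl)amino gives a 7.7-fold higher number from compound 2 to compound 3 (0.89 log units; beyond the scatter), toward lower toxicity in this test. Going by these compounds alone, this is the first single change that can be read, and it shows that the aromatic carbon meta to a chloro group can carry a step beyond the scatter, even though the leaving and entering groups have the same count of heavy atoms. The exchange swaps two three-membered non-aromatic rings of carbon for a six-membered aromatic ring with one hetero atom and adds hydrogen-bond donors and acceptors, but no measurement at hand gives a reason for the step or singles out which of these differences goes with it.

The compounds shown leave open whether a benzylamino group or a (pyridin-3-yl)methylamino group, neither carrying the hydroxy group, would move the number as far, and so which part of the entering group goes with the step. They also leave open where a single cyclopropylmethylamino group would fall on this read-out.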